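Cytotoxicity limits and a trifluoromethyl change on compound 2

The source may hold more compounds than are shown below. What is called first, only, known or untested is meant among the compounds shown, and "the series" means these compounds.

compound 1 `CNC(=O)c1cc2ncn(-c3ccc(C#N)cc3)c2cc1Oc1c(C)cc(CCC#N)cc1C` gives > 890000 nM
compound 2 `Cc1cc(/C=C/C#N)cc(C)c1Oc1cc(Nc2ccc(C#N)cc2)c(N)cc1S(N)(=O)=O` gives > 21800 nM
compound 3 `Cc1cc(CCC#N)cc(C)c1Oc1cc(Nc2ccc(C#N)cc2)c(N)cc1N` gives > 25000 nM

All three entries come from an ADME assay on TZM cells (Homo sapiens) for cytotoxicity, read by XTT assay, with a stated time of 4 days (on this read-out higher numbers stand for lower toxicity in this test and lower numbers for higher toxicity in this test), and each is a limit of the assay, not a number. Compound 2 reads > 21800 nM as a limit, so no number fixes its place in the series. Compound 4 `Cc1cc(/C=C/C#N)cc(C)c1Oc1cc(Nc2ccc(C#N)cc2)c(N)cc1C(F)(F)F` differs from compound 2 at one place. The change trifluoromethyl in place of sulfamoyl on an aromatic carbon puts trifluoromethyl in place of sulfamoyl on an aromatic carbon, para to a (4-cyanophenyl)amino group. Among the compounds with values here, no measured pair shows a single change, so the expectation rests on thin ground. Compound 3, which carries no sulfamoyl, also gives only a limit, > 25000 nM in this assay. The estimated step that the limit leaves unreadable from compound 2 to compound 4 is expected to stay within the usual scatter, with no direction favoured. Compound 4 is estimated at 22000 nM (7000 nM to 60000 nM), and a reading reported only as a limit is expected.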

Compound 4, half-maximal cytotoxic concentration: 15000 nM
Compound 4: the middle estimate sits 1.5-fold (0.17 log units) above what was measured; measured number inside the range.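

In this assay compound 4 gives 15000 nM, the only reading among the compounds shown that is a number and not a limit. At this position, on an aromatic carbon para to a (4-cyanophenyl)amino group, trifluoromethyl in place of sulfamoyl gives an at least 1.4-fold lower number from compound 2 to compound 4 (0.16 log units; that floor lies within the scatter). The value of compound 2 is a limit, so this step is only a floor and its full size cannot be read: the limit of > 21800 nM in this assay, at which 1 of the 4 values shown sits.

As far as these compounds go, whether a carboxylic acid, a primary amide or a methylsulfonyl group at this position would read as a number or as a limit remains open. The compounds shown hold no pair with a number on both sides, so how much of the reading of compound 4 belongs to trifluoromethyl also stays open.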